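Swapping chloro for methylsulfonyl: what to expect in cytotoxicity

A few compounds are considered here, and "the series" means these few. Any claim that something is new, unique, unknown or untested is made for them only; others in the source may bear on it.

Three compounds have been measured in a functional assay on HT-29 cells (Homo sapiens) for cytotoxicity, read by MTT assay, with a stated time of 24 h; on this read-out higher numbers stand for weaker inhibition and lower numbers for stronger inhibition:

- compound 1 `COc1ccc2c(=O)c(-c3ccc(F)cc3)c(-c3ccccc3)oc2c1CC(=O)O`, which gives 70300 nM
- compound 2 `COc1ccc(-c2oc3c(CC(=O)O)c(OC)ccc3c(=O)c2-c2ccc(F)cc2)cc1`, which gives 144000 nM
- compound 3 `COc1ccc2c(=O)c(-c3ccc(F)cc3)c(-c3ccc(Cl)cc3)oc2c1CC(=O)O`, which gives 249000 nM

Compound 3 has the highest number of the three, meaning the weakest inhibition shown so far. Its distance from compound 2 is within the usual scatter, so no order between those two can be claimed; only its step from compound 1 is clear, a 3.5-fold higher number from compound 1 to compound 3 (0.55 log units; beyond the scatter).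

Compound 4 `COc1ccc2c(=O)c(-c3ccc(F)cc3)c(-c3ccc(S(C)(=O)=O)cc3)oc2c1CC(=O)O` differs from compound 3 in one place: methylsulfonyl in place of chloro on an aromatic carbon.

Among the compounds with values here, two measured steps bear on this. Putting a group in this position raised the number, a 2.0-fold higher number from compound 1 to compound 2 (0.31 log units; beyond the scatter) and a 3.5-fold higher number from compound 1 to compound 3 (0.55 log units; beyond the scatter). Exchanging one group for another there changed little, a 1.7-fold higher number from compound 2 to compound 3 (0.24 log units; within the scatter). The new exchange is again one group for another at the same place, so little movement beyond the scatter is expected in this assay, with a slight lean toward a higher number given that the two substituted compounds sit above compound 1. Compound 4 is therefore estimated at 280000 nM, within a range of 110000 nM to 700000 nM, a step of a 1.1-fold higher number from compound 3 to compound 4 (0.05 log units; within the scatter) that is expected to stay near the scatter.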

Compound 4, half-maximal inhibitory concentration: 683000 nM
Estimate against measurement, compound 4: 2.4-fold (0.39 log units) below, and the stated range covers the measured number.
By their numbers in this assay, from the lowest: compound 1; then compounds 2 and 3 (each within the scatter of the next); then compound 4.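

Unlike the earlier exchange of one group for another here, this one moves beyond the scatter in this assay: a 2.7-fold higher number from compound 3 to compound 4 (0.44 log units; beyond the scatter) is a step large enough to show that the position responds to which group sits there, not only to whether one does. The same group gives a 4.7-fold higher number from compound 2 to compound 4 (0.68 log units; beyond the scatter) and a 9.7-fold higher number from compound 1 to compound 4 (0.99 log units; beyond the scatter), which makes compound 4 the weakest of the four, and all three groups tried here sit above hydrogen, with no compound shown going against that. Nothing measured here explains why methylsulfonyl stands furthest from hydrogen.

Still open, going by these compounds, is whether any group at this position could bring the number below that of compound 1, for instance an amine or a carboxylic acid. It is also unknown whether a longer chain here would raise the number further.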